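Aryl ether variation in the cyclohexyl diarylurea series

This account rests on a few compounds, and the source may have more. Where it says the series, first, only, none or still open, it means among the compounds named here.

The two measured compounds share a core of compound 1 `O=C(Nc1cccc(C(F)(F)F)c1)N[C@H]1CC[C@H](Oc2cccc(C(F)(F)F)c2)CC1`, which in a functional assay on CRL2813 cells (Homo sapiens) for antiproliferative activity, read by sulforhodamine B assay, with a stated time of 3 days, in the presence of a further agent that is not named here (a higher number here means a weaker inhibitor, a lower number a stronger inhibitor), gives 1050 nM. Compound 2 `O=C(Nc1cccc(C(F)(F)F)c1)N[C@H]1CC[C@H](Oc2ccc(C(F)(F)F)cc2)CC1` gives 660 nM in this assay; the step of a 1.6-fold lower number from compound 1 to compound 2 (0.20 log units; within the scatter) shows the two numbers sit together, so no order between them is claimed. Compound 3 `O=C(Nc1cccc(C(F)(F)F)c1)N[C@H]1CC[C@H](Oc2cccc(F)c2)CC1` is not yet measured; it differs from compound 2 in that (3-fluorophenyl in place of 4-(trifluoromethyl)phenyl on an oxygen on a saturated carbon). Within the data shown here, the only measured step, from compound 1 to compound 2, moves the trifluoromethyl within the aryl ether and stays within the scatter; no measured step exchanges trifluoromethyl for fluorine, so the size of that exchange is unknown here. Given that the one aryl-ether change seen did little, compound 3 is expected to give 900 nM in this assay, in the range 350 nM to 2500 nM. The expected step of a 1.4-fold higher number from compound 2 to compound 3 (0.13 log units; within the scatter) is therefore estimated as not clearly beyond the scatter.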

Compound 3, half-maximal inhibitory concentration: 4300 nM
Estimate against measurement, compound 3: 4.8-fold (0.68 log units) below; measured number outside the range, above it.
By their numbers in this assay, from the lowest: compounds 2 and 1 (each within the scatter of the next); then compound 3.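

In this assay, the aryl ether is not indifferent to its substituent, as the step between the two trifluoromethyl isomers alone might have suggested: fluoro in place of trifluoromethyl on an aromatic carbon gives a 4.1-fold higher number from compound 1 to compound 3 (0.61 log units; beyond the scatter). The exchange of 4-(trifluoromethyl)phenyl for 3-fluorophenyl on the same oxygen gives a 6.5-fold higher number from compound 2 to compound 3 (0.81 log units; beyond the scatter), so among these three compounds the two trifluoromethyl ethers stay together and the fluoro ether stands apart, with no compound here going against that. Nothing available bears on why this exchange raises the number.

From the compounds shown here alone, whether a 4-fluorophenyl ether would repeat the step seen from the 3-(trifluoromethyl)phenyl ether remains open. Also open, going by these compounds, is where an unsubstituted phenyl, or a ring carrying a methoxy, nitrile or carboxylic acid, would fall relative to compound 3.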